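The source may hold more compounds than are shown below. What is called first, only, known or untested is meant among the compounds shown, and "the series" means these compounds.

Measured compounds:
compound 1, `c1ccc(-c2nc(-c3ccc4nc[nH]c4c3)no2)cc1`, gives 5.26 10^-6 cm/s in a physicochemical assay for permeability, using PAMPA, at pH 7.4; a lower number here means that the compound crosses the layer more slowly, a higher number that the compound crosses the layer faster;
compound 2, `Brc1ccc(-c2nc(-c3ccc4nc[nH]c4c3)no2)cc1`, gives 11.2 10^-6 cm/s;
compound 3, `Fc1ccc(-c2nc(-c3ccc4nc[nH]c4c3)no2)cc1`, gives 19.6 10^-6 cm/s.

Compound 3 holds the largest of the three numbers. Its separation from compound 1 is clear, since a 3.7-fold higher number from compound 1 to compound 3 (0.57 log units; beyond the scatter). Its separation from compound 2 is not, since a 1.8-fold higher number from compound 2 to compound 3 (0.24 log units; within the scatter), so compound 2 and compound 3 cannot be told apart on these numbers; a 2.1-fold higher number from compound 1 to compound 2 (0.33 log units; beyond the scatter) places compound 2 apart from compound 1 only.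

Compound 4, `OCCCCCc1ccc(-c2nc(-c3ccc4nc[nH]c4c3)no2)cc1`, is still to be measured. It differs from compound 3 in one place: 5-hydroxypentyl in place of fluoro on an aromatic carbon. For the measured compounds named here, the only measured steps that bear on this are the ones that set the fluoro in: a 3.7-fold higher number from compound 1 to compound 3 (0.57 log units; beyond the scatter) tells what the fluoro added over hydrogen, and a 2.1-fold higher number from compound 1 to compound 2 (0.33 log units; beyond the scatter) gives a second substituent at the same carbon. Going by the values given here, no measured step shows a chain entering at this carbon, nor a group carrying a hydrogen-bond donor and acceptor, so the entering 5-hydroxypentyl is uncharted. Taking the fluoro away alone would be expected to return the number toward that of compound 1. On this basis compound 4 is expected to show a lower number than compound 3, about a 3.0-fold lower number from compound 3 to compound 4 (0.48 log units; beyond the scatter). The estimate for compound 4 is 6.5 10^-6 cm/s, with a range from 2.5 10^-6 cm/s to 16 10^-6 cm/s.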

Compound 4, apparent permeability: 7.75 10^-6 cm/s
The estimate for compound 4 lay 1.2-fold (0.08 log units) below the measured number; the measured number falls inside the stated range.
By their numbers in this assay, from the lowest: compounds 1, 4, 2 and 3 (each within the scatter of the next, the first and the last beyond it).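

At the position on an aromatic carbon para to a large group, earlier compounds carried only hydrogen, bromo or fluoro; compound 4 shows that in this assay this position also takes 5-hydroxypentyl, a chain of 6 heavy atoms with a hydrogen-bond donor and acceptor, and that putting it in place of fluoro gives a 2.5-fold lower number from compound 3 to compound 4 (0.40 log units; beyond the scatter) as a step beyond the scatter. The same chain does not separate from the other two substituents, since a 1.4-fold lower number from compound 2 to compound 4 (0.16 log units; within the scatter) and a 1.5-fold higher number from compound 1 to compound 4 (0.17 log units; within the scatter) are both within the scatter, so compound 4 cannot be told apart from compound 2 or compound 1, and among the changes shown only the exchange with fluoro moves the number clearly. No measurement in hand explains why this exchange gives the step seen.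

Still open, as far as these compounds go, is whether the chain itself or its terminal hydroxyl sets the number, which a plain pentyl group at the same carbon would address. Also open, from the compounds shown here alone, is how a shorter or longer chain, or an amine or carboxylic acid at the chain end, would read in this assay at this position.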